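Aryl swap on the piperazine nitrogen of compound 3

The compounds below may be only part of what the source reports. "The series", "measured", "known", "first", "only" and "open" are said of these compounds alone.

Compound 3 `Fc1cccc(F)c1N1CCN(Cc2ccn3c(CC4CC4)nnc3c2C(F)(F)F)CC1` in an assay on CHO cells for positive allosteric modulation of metabotropic glutamate receptor 2 (Homo sapiens), read by scintillation counting, with a stated time of 30 min (on this read-out lower numbers stand for an effect already at smaller amounts and higher numbers for an effect only at larger amounts of compound), gives 26 nM. Among the three measured compounds this is the second highest number; compound 2 `Fc1ccc([C@H]2CC[C@@H](NCc3ccn4c(CC5CC5)nnc4c3C(F)(F)F)CC2)c(F)c1` gives 38 nM, within the scatter of compound 3, and compound 1 `Fc1ccccc1C1CCN(Cc2ccn3c(CC4CC4)nnc3c2C(F)(F)F)CC1` gives 15 nM, also within the scatter. For the measured compounds named here, these three differ from one another in more than one place, so no single step can be separated out. Compound 4 `FC(F)(F)c1c(CN2CCN(c3ccc(Cl)cc3Cl)CC2)ccn2c(CC3CC3)nnc12` carries 2,4-dichlorophenyl in place of 2,6-difluorophenyl on an amine nitrogen in a ring. Going by the values given here, no measured pair isolates such an aryl exchange, so nothing in the set points to a step beyond the scatter in either direction. The step expected here is a 1.2-fold higher number from compound 3 to compound 4 (0.06 log units; within the scatter). Compound 4 is expected to give about 30 nM, in the range 10 nM to 90 nM.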

Compound 4, half-maximal effective concentration: 17 nM
Estimate against measurement, compound 4: 1.8-fold (0.25 log units) above, within the range that was stated.
By their numbers in this assay, from the lowest: compounds 1, 4, 3 and 2 (each within the scatter of the next, the first and the last beyond it).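

For the compounds shown here, exchanging 2,6-difluorophenyl for 2,4-dichlorophenyl on the amine nitrogen in the ring gives the first single-place step: a 1.5-fold lower number from compound 3 to compound 4 (0.18 log units; within the scatter) in this assay. This position therefore accepts either of these two dihalogenated phenyl groups without a step beyond the scatter. Nothing available on this series offers an explanation for the result.

As far as these compounds go, both groups carry two halogens, so what an unsubstituted phenyl, a methoxyphenyl or a pyridyl would do on this nitrogen remains open. Also open, from the compounds shown here alone, is whether each chlorine contributes separately.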